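The source may hold more compounds than are shown below. What is called first, only, known or untested is meant among the compounds shown, and "the series" means these compounds.

Measured compounds:
compound 1, `Cn1nccc1-c1cnc(NCc2c(F)ccc3c2CCO3)c2cn[nH]c(=O)c12`, 2.6
compound 2, `CN(C(=O)c1ccccc1)c1cnc(NCc2c(F)ccc3c2CCO3)n2cnnc12`, 2.4
compound 3, `O=C(Nc1cnc(NCc2c(F)ccc3c2CCO3)n2cnnc12)c1ccccc1`, 3

In a physicochemical assay for lipophilicity, using the shake flask method, in phosphate buffer, measured as octanol-water partition, with a stated time of 30 min, at pH 7.4 (on this read-out higher numbers stand for higher lipophilicity and lower numbers for lower lipophilicity), compound 1 gives 2.6. Compound 2 gives 2.4, a number within the scatter of compound 1, so the two cannot be told apart. Compound 3, at 3, stands beyond the scatter above compound 1 and is the highest of the three. Going by the values given here, the only step recorded between measured compounds is a number 0.60 log units higher from compound 2 to compound 3 (beyond the scatter).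

Compound 4, `CNC(=O)c1cc(-c2cnc(NCc3c(F)ccc4c3CCO4)c3cn[nH]c(=O)c23)n(C)n1`, is not yet measured. It differs from compound 1 by methylcarbamoyl in place of hydrogen on an aromatic carbon. Among the compounds with values here, no measured step matches this change: the step from compound 2 to compound 3 concerns hydrogen in place of methyl on an amide-type nitrogen, not methylcarbamoyl in place of hydrogen on an aromatic carbon. The data therefore give no direct guide. On general grounds the group that enters carries one hydrogen-bond donor and one hydrogen-bond acceptor, which more often lowers than raises a number in this assay. Compound 4 is therefore expected to give a somewhat lower number, a step of a number 0.40 log units lower from compound 1 to compound 4 (beyond the scatter). The estimate for compound 4 in this assay is 2.2, with a range from 1.7 to 2.7.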

Compound 4, distribution coefficient: 2.1
Estimate against measurement, compound 4: 0.10 log units above; measured number inside the range.
By their numbers in this assay, from the lowest: compounds 4, 2 and 1 (each within the scatter of the next, the first and the last beyond it); then compound 3.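

In this assay, methylcarbamoyl on this aromatic carbon of the five-membered aromatic ring with 2 nitrogen gives a number 0.50 log units lower from compound 1 to compound 4 (beyond the scatter). Going by these compounds alone, this is the first reading at this place: among the earlier compounds, only compound 1 carries the 1-methyl-1H-pyrazol-5-yl group, and no earlier step touches it, so the result shows that a change on this carbon can move the read-out beyond the scatter, by a modest step. No measured evidence shown here accounts for the size or direction of this step.

The compounds shown test a single group at this carbon, so it remains open whether a primary carboxamide, a dimethylcarbamoyl group, a nitrile or a carboxylic acid would move the number in the same direction or by a similar amount. As far as these compounds go, it also remains open whether the 1-methyl-3-(methylcarbamoyl)-1H-pyrazol-5-yl group would give a similar step on another core, or whether a longer chain on the amide nitrogen would keep the step seen with methylcarbamoyl.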